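A morpholine-to-oxazolamine swap carried onto a second core

The compounds below may be only part of what the source reports. "The series", "measured", "known", "first", "only" and "open" are said of these compounds alone.

In a functional assay on DU-145 cells (Homo sapiens) for inhibition, read by MTT assay, with a stated time of 48 h (on this read-out lower numbers stand for stronger inhibition and higher numbers for weaker inhibition), compound 2 `CC1CN(C(=O)CN2C(=O)S/C(=C\c3nc4ccccc4n3C)C2=O)CC(C)O1` gives only a limit of the assay, > 50000 nM. Compound 1 `Cn1c(/C=C2\SC(=O)N(CC(=O)Nc3cc(C(C)(C)C)on3)C2=O)nc2ccccc21` gives 31400 nM in this assay. Between these two the change is (5-(tert-butyl)-1,2-oxazol-3-yl)amino in place of 2,6-dimethylmorpholin-4-yl on a carbonyl carbon, and it brought an at least 1.5-fold lower number from compound 2 to compound 1 (0.20 log units; that floor lies within the scatter). Compound 3 `CC1CN(C(=O)CN2C(=O)S/C(=C\c3nc4ccccc4n3C(C)C)C2=O)CC(C)O1` also gives only a limit, > 50000 nM. Its core differs from the core of compound 2 by isopropyl in place of methyl on an aromatic nitrogen, which gave a step that the two limits leave unreadable from compound 2 to compound 3; the reason is the limit of > 50000 nM in this assay, at which 2 of the 3 values shown sit. Compound 4 `CC(C)n1c(/C=C2\SC(=O)N(CC(=O)Nc3cc(C(C)(C)C)on3)C2=O)nc2ccccc21` is not yet measured and differs from compound 3 by (5-(tert-butyl)-1,2-oxazol-3-yl)amino in place of 2,6-dimethylmorpholin-4-yl on a carbonyl carbon, the same change seen between compound 2 and compound 1. Compound 4 is expected to give about 35000 nM, likely between 15000 nM and 80000 nM. That expectation rests on an at least 1.5-fold lower number from compound 2 to compound 1 (0.20 log units; that floor lies within the scatter), and the estimated step is an at least 1.4-fold lower number from compound 3 to compound 4 (0.15 log units; that floor lies within the scatter).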

Compound 4, half-maximal inhibitory concentration: > 50000 nM
Compound 4 ended at the assay's limit (the forecaster's own chance of this, stated with the estimate: 40%); middle value at least 1.4-fold (0.15 log units) from the limit.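

In this assay compound 4 gives only a limit, > 50000 nM. Among the compounds shown here, the step from compound 3 to compound 4 cannot be read, because neither compound gives a number, only a limit: the limit of > 50000 nM in this assay, at which 3 of the 4 values shown sit. The one readable step, for isopropyl in place of methyl on an aromatic nitrogen, is an at least 1.5-fold higher number from compound 1 to compound 4 (0.20 log units; that floor lies within the scatter), so the data show neither that the oxazolamine swap carries over to the second core nor that it fails there.

From the compounds shown here alone, with a number for compound 1 alone, how much the swap or the isopropyl group matters stays open. Going by these compounds, it also stays open whether ethyl in place of methyl on the aromatic nitrogen would give a measurable value with the oxazolamine kept.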